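Replacing 4-(methylsulfonyl)phenyl with furan-2-yl in compound 2

The source may report more compounds than this note shows. Statements on the series, on what has been measured and on what is new or still open speak of the compounds shown alone.

In a functional assay on HCT-116 cells (Homo sapiens) for antiproliferative activity, read by MTT assay (a lower number here means a stronger inhibitor, a higher number a weaker inhibitor), three compounds sharing one core have been measured so far. Compound 1 (`Cn1c(=O)c(=O)n(C2CCCC2)c2nc(N/N=C/c3ccc(O)cc3)ncc21`) gives 72500 nM in this test. Compound 2 (`Cn1c(=O)c(=O)n(C2CCCC2)c2nc(N/N=C/c3ccc(S(C)(=O)=O)cc3)ncc21`) gives 86600 nM and so belongs at the high, weaker end of the numbers seen here, level with compound 1 once the scatter is taken into account. The step between them is a 1.2-fold higher number from compound 1 to compound 2 (0.08 log units; within the scatter) and it comes from methylsulfonyl standing in place of hydroxy on an aromatic carbon. Compound 3 (`Cn1c(=O)c(=O)n(C2CCCC2)c2nc(N/N=C/c3cc(C(F)(F)F)c(O)c(C(F)(F)F)c3)ncc21`) gives 27100 nM which is clearly a lower number than compound 2 shows.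

Compound 4 (`Cn1c(=O)c(=O)n(C2CCCC2)c2nc(N/N=C/c3ccco3)ncc21`) has furan-2-yl in place of 4-(methylsulfonyl)phenyl on a carbon with a double bond to nitrogen. This is a larger change than any measured so far, since the whole aromatic group is exchanged. Within the data shown here, no measured compound has a five-membered aromatic ring at this place, so the data offer only indirect guidance. Among the measured compounds shown here, the one measured single change, a 1.2-fold higher number from compound 1 to compound 2 (0.08 log units; within the scatter) barely moved the number, which argues against expecting a large shift. The expected change is a 1.4-fold lower number from compound 2 to compound 4 (0.16 log units; within the scatter) and it is only a rough estimate. For compound 4 the estimated value is 60000 nM with an expected range of 25000 nM to 130000 nM for this measurement.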

Compound 4, half-maximal inhibitory concentration: 78700 nM
Estimate against measurement, compound 4: 1.3-fold (0.12 log units) below; measured number inside the range.
By their numbers in this assay, from the lowest: compound 3; then compounds 1, 4 and 2 (each within the scatter of the next).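

In this assay, furan-2-yl in place of 4-(methylsulfonyl)phenyl gives a 1.1-fold lower number from compound 2 to compound 4 (0.04 log units; within the scatter), and furan-2-yl in place of 4-hydroxyphenyl gives a 1.1-fold higher number from compound 1 to compound 4 (0.04 log units; within the scatter). The earlier compounds shown here only compared two groups on a six-membered aromatic ring of carbon only, whereas these steps show that a five-membered aromatic ring with 1 hetero atom, with fewer heavy atoms than 4-(methylsulfonyl)phenyl, reads level with both at this place on the carbon with a double bond to nitrogen. Nothing available here explains why the numbers stay level across so large an exchange of groups.

This flat picture covers only compounds 1, 2 and 4 and does not extend to compound 3, which carries two trifluoromethyl groups beside its hydroxy group and gives 27100 nM, so the aromatic group at this place can matter in some form. On these data alone, it remains open whether an amine or a carboxylic acid on the ring, or a longer chain in place of the ring, would read level with these compounds or would move the number beyond the scatter.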